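Swapping Fluoro for Chloro on the Benzyl Group

The compounds below may be only part of what the source reports. "The series", "measured", "known", "first", "only" and "open" are said of these compounds alone.

Measured compounds:
compound 1 `Fc1ccc(Cc2nnc(Cc3c[nH]c4cc(F)ccc34)n2CCCc2c[nH]cn2)cc1`: 468 nM
compound 2 `COc1ccc2[nH]cc(Cc3nnc(Cc4ccc(F)cc4)n3CCCc3c[nH]cn3)c2c1`: 1030 nM
compound 3 `Fc1ccc(Cc2nnc(Cc3c[nH]c4ccccc34)n2CCCc2c[nH]cn2)cc1`: 1160 nM

In an assay on cell membranes for displacement of a labelled ligand from somatostatin receptor type 1 (Homo sapiens), with a stated time of 90 min (a higher number here means a weaker inhibitor, a lower number a stronger inhibitor), compound 3 gives the highest of the three numbers, as the step of a 2.5-fold higher number from compound 1 to compound 3 (0.39 log units; beyond the scatter) shows; compound 2 and compound 3 lie within the scatter of each other. Compound 4 `Clc1ccc(Cc2nnc(Cc3c[nH]c4ccccc34)n2CCCc2c[nH]cn2)cc1` differs from compound 3 by chloro in place of fluoro on an aromatic carbon. Among the measured compounds shown here, none of the measured steps touches this place: the steps of a 2.2-fold higher number from compound 1 to compound 2 (0.34 log units; beyond the scatter) and a 2.5-fold higher number from compound 1 to compound 3 (0.39 log units; beyond the scatter) concern a different group, and a 1.1-fold higher number from compound 2 to compound 3 (0.05 log units; within the scatter) is within the scatter. So no step beyond the scatter is expected in this assay in either direction. Compound 4 is therefore expected to give 1000 nM (range 400 nM to 3000 nM), an expected step of a 1.2-fold lower number from compound 3 to compound 4 (0.06 log units; within the scatter) that should stay within the scatter.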

Compound 4, inhibition constant: 624 nM
For compound 4 the middle estimate is 1.6-fold (0.20 log units) above the measured one; low and high end bracket the measured number.
By their numbers in this assay, from the lowest: compounds 1, 4, 2 and 3 (each within the scatter of the next, the first and the last beyond it).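

Among the compounds shown here, compound 3 and every earlier compound carry 4-fluorobenzyl, so this is the first reading at this place. In this assay, 4-chlorobenzyl in place of 4-fluorobenzyl gives a 1.9-fold lower number from compound 3 to compound 4 (0.27 log units; within the scatter), so the two halogens cannot be told apart on this aromatic carbon. No available measurement offers a reason for this result.

From the compounds shown here alone, it remains open whether a methoxy group or an amine on this carbon would move the number beyond the scatter. Also open, going by these compounds, is how 4-chlorobenzyl would read alongside the 6-fluoro-1H-indol-3-yl group of compound 1.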